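From cyclohexyl to 4-nitrophenyl on a carbonyl carbon

A few compounds are considered here, and "the series" means these few. Any claim that something is new, unique, unknown or untested is made for them only; others in the source may bear on it.

Compound 1 `CCCCC(=O)OCCc1c(-c2ccccc2Cl)c2cc(Cl)ccc2[nH]c1=O` gives 200000 nM
Compound 2 `CCCCCCCC(=O)OCCc1c(-c2ccccc2Cl)c2cc(Cl)ccc2[nH]c1=O` gives 78000 nM
Compound 3 `O=C(OCCc1c(-c2ccccc2Cl)c2cc(Cl)ccc2[nH]c1=O)C1CCCCC1` gives 38000 nM

In an ADME assay on HepG2 2.2.15 cells (Homo sapiens) for cytotoxicity (on this read-out higher numbers stand for lower toxicity in this test and lower numbers for higher toxicity in this test), compound 3 stands lowest of the three at 38000 nM on this scale. Compound 4 `O=C(OCCc1c(-c2ccccc2Cl)c2cc(Cl)ccc2[nH]c1=O)c1ccc([N+](=O)[O-])cc1` has 4-nitrophenyl in place of cyclohexyl on a carbonyl carbon. Two measured steps changed the group on this carbonyl carbon (a 5.3-fold lower number from compound 1 to compound 3 (0.72 log units; beyond the scatter) and a 2.1-fold lower number from compound 2 to compound 3 (0.31 log units; beyond the scatter)). Both were modest, and neither brought in an aromatic ring. They therefore give no direction, so no step beyond the scatter is expected in this assay and the expected size is small (a 1.2-fold higher number from compound 3 to compound 4 (0.07 log units; within the scatter)). Compound 4 is estimated at 45000 nM with an expected range of 14000 nM to 140000 nM for this measurement.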

Compound 4, half-maximal cytotoxic concentration: 1600000 nM
Estimate against measurement, compound 4: 36-fold (1.55 log units) below; the whole stated range lies below it.
By their numbers in this assay, from the lowest: compound 3; then compound 2; then compound 1; then compound 4.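

In this assay, this carbonyl carbon proves far more sensitive than the saturated groups suggested: 4-nitrophenyl gives (a 42-fold higher number from compound 3 to compound 4 (1.62 log units; beyond the scatter)), (a 21-fold higher number from compound 2 to compound 4 (1.31 log units; beyond the scatter)) and (an 8.0-fold higher number from compound 1 to compound 4 (0.90 log units; beyond the scatter)). All three steps run upward, so compound 4 stands highest of the four, and the change is not confined to replacing cyclohexyl. Nothing at hand explains this rise.

Going by these compounds, whether the rise follows the aromatic ring or the nitro group stays open. Phenyl or 4-aminophenyl on this carbonyl carbon would separate the two.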